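This account rests on a few compounds, and the source may have more. Where it says the series, first, only, none or still open, it means among the compounds named here.

Measured so far:
Compound 1, `C=C1CC[C@@H]2[C@](C)(CO)[C@H](O)CC[C@@]2(C)[C@@H]1CCC1=CCOC1=O`: in a functional assay on NP14 cells (Homo sapiens) for cytotoxicity, read by MTT assay, with a stated time of 48 h (on this read-out lower numbers stand for stronger inhibition and higher numbers for weaker inhibition), compound 1 gives > 100000 nM, which is a limit of the assay and not a number.
Compound 2, `C=C1CC[C@@H]2[C@](C)(CO)[C@H](O)CC[C@@]2(C)[C@@H]1CCc1ccoc1`: compound 2 gives 53300 nM.
Compound 3, `C=C1CC[C@@H]2[C@](C)(COC(=O)C(Cl)Cl)[C@H](OC(=O)C(Cl)Cl)CC[C@@]2(C)[C@@H]1CCc1ccoc1`: compound 3 gives 4430 nM.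

Among the two numbers on hand, compound 2 gives the higher one, and compound 3 stands well lower. Compound 4, `C=C1CC[C@@H]2[C@](C)(COC(=O)c3ccc(OC)cc3)[C@H](O)CC[C@@]2(C)[C@@H]1CCc1ccoc1`, has not yet been measured. It differs from compound 2 by (4-methoxyphenyl)carbonyl in place of hydrogen on an oxygen on a saturated carbon. Among the compounds with values here, the one measured single step, an at least 1.8-fold lower number from compound 1 to compound 2 (0.27 log units; that floor lies within the scatter), alters a different part of the shared core and leaves both oxygens untouched, so it says little about this change. Compound 3 carries acyl groups on both oxygens of compound 2 and gives a lower number than compound 2, but it differs in two places, so its value is only a loose guide. Since that is the nearest comparison, compound 4 is expected to show a moderately lower number than compound 2, a step of a 3.6-fold lower number from compound 2 to compound 4 (0.55 log units; beyond the scatter). The estimate for compound 4 is 15000 nM, with a range from 4000 nM to 55000 nM.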

Compound 4, half-maximal inhibitory concentration: 40400 nM
Estimate against measurement, compound 4: 2.7-fold (0.43 log units) below, within the range that was stated.
By their numbers in this assay, from the lowest: compound 3; then compounds 4 and 2 (each within the scatter of the next). At a limit, above all of these: compound 1.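

Replacing hydroxy with ((4-methoxyphenyl)carbonyl)oxy, on an oxygen on a saturated carbon, gives a 1.3-fold lower number from compound 2 to compound 4 (0.12 log units; within the scatter) in this assay. On this read-out, compound 2 and compound 4 therefore cannot be told apart, even though the new group brings an aromatic ring and a carbonyl to a place that held only a hydrogen. None of the information on hand bears on why this swap leaves the two compounds so close.

From the compounds shown here alone, one added group gives only one view of this oxygen, so it remains open whether a small acetyl group, a longer chain or a group carrying an amine would also leave the number within the scatter. Also open, going by these compounds, is how the same (4-methoxyphenyl)carbonyl would behave on the second hydroxy of compound 2.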